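This account rests on a few compounds, and the source may have more. Where it says the series, first, only, none or still open, it means among the compounds named here.

Measured so far in a functional assay on HCT-116 cells (Homo sapiens) for cytotoxicity, with a stated time of 3 days; a lower number here means that less compound is needed, a higher number that more compound is needed for the effect: compound 1 `O=c1cc(-c2c[nH]c3ncccc23)nc(-c2ccccc2)[nH]1` gives 830 nM; compound 2 `O=c1cc(-c2c[nH]c3ncccc23)nc(NC2CCCCC2)[nH]1` gives 103 nM; compound 3 `CN(c1nc(-c2c[nH]c3ncccc23)cc(=O)[nH]1)C1CCCCC1` gives 106 nM.

Compound 3 stands second highest of the three numbers, indistinguishable from compound 2 and well below compound 1, as a 7.8-fold lower number from compound 1 to compound 3 (0.89 log units; beyond the scatter) shows. Compound 4 `O=c1cc(-c2c[nH]c3ncccc23)nc(Nc2ccccc2)[nH]1` differs from compound 3 by anilino in place of cyclohexyl(methyl)amino on an aromatic carbon. Bearing on this: an 8.1-fold lower number from compound 1 to compound 2 (0.91 log units; beyond the scatter) and a 7.8-fold lower number from compound 1 to compound 3 (0.89 log units; beyond the scatter) show that an amino-linked substituent in place of a directly attached phenyl gives a modest gain, and a 1.0-fold higher number from compound 2 to compound 3 (0.01 log units; within the scatter) shows the methyl on the nitrogen is neutral. Within the data shown here, no measured pair swaps the saturated ring for an aromatic one on that amine, so the direction is uncertain; a step of a 1.9-fold higher number from compound 3 to compound 4 (0.28 log units; within the scatter) in this assay is expected, with a wide range. Compound 4 is estimated at 200 nM, between 50 nM and 800 nM.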

Compound 4, half-maximal effective concentration: 443 nM
Compound 4: middle estimate off by 2.2-fold (0.35 log units), on the low side, within the range that was stated.
By their numbers in this assay, from the lowest: compounds 2 and 3 (each within the scatter of the next); then compounds 4 and 1 (each within the scatter of the next).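

On the aromatic carbon between two ring nitrogen atoms, the nature of the ring on the amine matters in this assay: phenyl in place of cyclohexyl gives a 4.3-fold higher number from compound 2 to compound 4 (0.63 log units; beyond the scatter), and anilino in place of cyclohexyl(methyl)amino gives a 4.2-fold higher number from compound 3 to compound 4 (0.62 log units; beyond the scatter). The nitrogen link alone does not reproduce the earlier improvement, since anilino in place of phenyl gives only a 1.9-fold lower number from compound 1 to compound 4 (0.27 log units; within the scatter). Nothing available explains the difference between the saturated and aromatic rings.

Open, on these data alone, is whether a cyclopentyl ring, a piperidine or an open chain such as butyl on this amine matches compound 2. Also open, as far as these compounds go, is how a methoxy or fluoro group on the anilino phenyl would shift the number.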